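From Trifluoromethylphenyl to Phenylethenyl on the Acyl Carbon

A few compounds are considered here, and "the series" means these few. Any claim that something is new, unique, unknown or untested is made for them only; others in the source may bear on it.

Of the compounds shown here, three have been measured in a functional assay on MDA-MB-231 cells (Homo sapiens) for inhibition, read by sulforhodamine B assay, tested at 10 uM; on this read-out higher numbers stand for more inhibition at the one concentration tested (going by the name of the read-out) and lower numbers for less inhibition. Compound 1 `CC(=O)N1N=C(c2ccc(N3CCN(C)CC3)cc2)CC1c1ccc(N(C)C)cc1` gives -1%, compound 2 `CN1CCN(c2ccc(C3=NN(C(=O)CCCl)C(c4ccc(N(C)C)cc4)C3)cc2)CC1` gives 2.4%, and compound 3 `CN1CCN(c2ccc(C3=NN(C(=O)c4ccc(C(F)(F)F)cc4)C(c4ccc(N(C)C)cc4)C3)cc2)CC1` gives 55.4%, the highest of the three. The steps of a number 56.4 percentage points higher from compound 1 to compound 3 (beyond the scatter) and a number 53 percentage points higher from compound 2 to compound 3 (beyond the scatter) both show a large rise once a six-membered aromatic ring sits on the carbonyl carbon. Compound 4 `CN1CCN(c2ccc(C3=NN(C(=O)/C=C/c4ccccc4)C(c4ccc(N(C)C)cc4)C3)cc2)CC1` differs from compound 3 thus: 2-phenylethenyl in place of 4-(trifluoromethyl)phenyl on a carbonyl carbon. Within the data shown here, the entering group keeps a six-membered aromatic ring and adds one double bond outside aromatic rings; no measured step covers this exact change, so the expectation rests on the two large steps alone. A modest fall is expected for compound 4, a number 15.4 percentage points lower from compound 3 to compound 4 (beyond the scatter). The estimate for compound 4 in this assay is 40%, between 15% and 65%.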

Compound 4, a percentage reported as inhibition, at one concentration (the size of the read-out at that concentration, not a potency): 35.9%
Compound 4: the middle estimate sits 4.1 percentage points above what was measured, within the range that was stated.
By their numbers in this assay, from the lowest: compounds 1 and 2 (each within the scatter of the next); then compound 4; then compound 3.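

On this carbonyl carbon, the large rise does not depend on 4-(trifluoromethyl)phenyl: in this assay the 2-phenylethenyl group gives a number 36.9 percentage points higher from compound 1 to compound 4 (beyond the scatter) and a number 33.5 percentage points higher from compound 2 to compound 4 (beyond the scatter) against methyl and 2-chloroethyl. It does not keep the whole gain, however, giving a number 19.5 percentage points lower from compound 3 to compound 4 (beyond the scatter) against 4-(trifluoromethyl)phenyl. Nothing available here explains the difference between these two groups. On these data alone, what a plain phenyl or a saturated 2-phenylethyl group would give on this carbonyl carbon remains open. So does whether the double bond or the trifluoromethyl group accounts for the gap.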